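Swapping amino for chloro in a cytotoxicity read-out

A few compounds are considered here, and "the series" means these few. Any claim that something is new, unique, unknown or untested is made for them only; others in the source may bear on it.

Measured in an ADME assay on HEK293 cells (Homo sapiens) for cytotoxicity, with a stated time of 72 h; on this read-out higher numbers stand for an effect only at larger amounts of compound and lower numbers for an effect already at smaller amounts:
- Compound 1 `Cc1cc(NC(=O)Nc2ccc(OC(F)(F)F)cc2)c2ccccc2n1`: 14000 nM
- Compound 2 `Cc1cc(NC(=O)Nc2ccc(N)cc2)c2ccccc2n1`: > 25000 nM (a limit, not a number)

Compound 2 stands only at a limit, > 25000 nM. Compound 3 `Cc1cc(NC(=O)Nc2ccc(Cl)cc2)c2ccccc2n1` carries chloro in place of amino on an aromatic carbon, para to a large group: chloro in place of amino on an aromatic carbon. Among the measured compounds shown here, the one measured step that bears on this is an at least 1.7-fold higher number from compound 1 to compound 2 (0.25 log units; that floor lies within the scatter), which also involves the amino group. With compound 1 at 14000 nM as the nearest measured neighbour, a small step to lower numbers is expected in this assay, perhaps none beyond the scatter. The estimated step is an at least 1.7-fold lower number from compound 2 to compound 3 (0.25 log units; that floor lies within the scatter). For compound 3 the estimate is 14000 nM, with an expected range from 6000 nM to 25000 nM.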

Compound 3, half-maximal effective concentration: > 25000 nM
Compound 3: only a limit was reported; the forecaster's own chance of this, stated with the estimate: 25%; at least 1.7-fold (0.25 log units) between middle value and limit.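

In this assay compound 3 gives > 25000 nM, which is a limit and not a number. Among the compounds shown here, the one readable step is an at least 1.7-fold higher number from compound 1 to compound 3 (0.25 log units; that floor lies within the scatter), while the step between the two limits cannot be read. What is new is that amino is not the only group at this position to reach the top of the range, since chloro does too: the limit of > 25000 nM in this assay, at which 2 of the 3 values shown sit.

As far as these compounds go, how far compound 2 and compound 3 truly lie from each other stays open. Also open, from the compounds shown here alone, is whether methoxy or a carboxylic acid at this position would give a number under the limit.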